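This account rests on a few compounds, and the source may have more. Where it says the series, first, only, none or still open, it means among the compounds named here.

Series notes. Going by the values given here, in an in vitro assay on HEK293 cells with metabotropic glutamate receptor 2 (Rattus norvegicus) as the target, read by FLIPR, in the presence of a further agent that is not named here (a higher number here means that more compound is needed for the effect, a lower number that less compound is needed), compound 1 `Cn1c(CN2C[C@@H]3C(COc4ccccc4)[C@@H]3C2)nc2ccccc21` gives 24 nM, the lowest of the three numbers so far. Compound 3 `Cn1c(CN2C[C@@H]3C(COc4cccc(-c5ccccc5)c4)[C@@H]3C2)nc2ccccc21` gives 113 nM and compound 2 `c1ccc(OCC2[C@H]3CN(Cc4cnc5ccccc5c4)C[C@@H]23)cc1` gives 9750 nM; both stand beyond the scatter from compound 1. Among the compounds with values here, the single one-point step shows that phenyl in place of hydrogen on an aromatic carbon moves the number a 4.7-fold higher number from compound 1 to compound 3 (0.67 log units; beyond the scatter). Compound 4 `Cn1c(CN2C[C@@H]3C(COc4ccc(Cl)cn4)[C@@H]3C2)nc2ccccc21` differs from compound 1 by 5-chloropyridin-2-yl in place of phenyl on an oxygen on a saturated carbon. Within the data shown here, no measured step exchanges the aryl group on the ether oxygen, so the phenyl-addition step is only a loose guide; a shift of similar or smaller size, in either direction, is expected. For compound 4 the expected step is a 1.7-fold higher number from compound 1 to compound 4 (0.22 log units; within the scatter), giving an estimated 40 nM with a range of 10 nM to 160 nM.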

Compound 4, half-maximal effective concentration: 26 nM
Estimate against measurement, compound 4: 1.5-fold (0.19 log units) above, and the stated range covers the measured number.
By their numbers in this assay, from the lowest: compounds 1 and 4 (each within the scatter of the next); then compound 3; then compound 2.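

In this assay, 5-chloropyridin-2-yl in place of phenyl on an oxygen on a saturated carbon gives a 1.1-fold higher number from compound 1 to compound 4 (0.03 log units; within the scatter). Going by these compounds alone, this is the first measured exchange of the aryl group on that oxygen, and compound 1 and compound 4 stand within the scatter of each other despite the entering ring nitrogen and chlorine. No available evidence bears on this result.

The shown compounds do not separate the chlorine from the ring nitrogen. From the compounds shown here alone, how an amine or a carboxylic acid on this ring would read remains open.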